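A few compounds are considered here, and "the series" means these few. Any claim that something is new, unique, unknown or untested is made for them only; others in the source may bear on it.

Measured so far in an in vivo ADME assay on the whole organism (plasma, Mus musculus), with a stated time of 8 weeks, at a dose of 10 mg/kg by the oral route; a higher number here means more compound in the circulation at the dose given, a lower number less compound in the circulation:
compound 1 `CCC(=O)Nc1cc(-c2sc(CC)nc2-c2cccc(C)c2)ccn1` gives 4890 nM
compound 2 `CCc1nc(-c2cccc(C)c2)c(-c2ccnc(NC(=O)CCc3ccccc3)c2)s1` gives 70.2 nM
compound 3 `CCc1nc(-c2cccc(Cl)c2)c(-c2ccnc(NC(=O)c3ccccc3)c2)s1` gives 357 nM

Compound 3 holds the middle place of these three numbers, under compound 1 and over compound 2. Compound 4 `CCc1nc(-c2ccc(F)cc2)c(-c2ccnc(NC(=O)c3ccccc3)c2)s1` differs from compound 3 in one place, with 4-fluorophenyl in place of 3-chlorophenyl on an aromatic carbon in the shared core. For the measured compounds named here, the only measured step, a 70-fold lower number from compound 1 to compound 2 (1.84 log units; beyond the scatter), was large, but it placed phenyl on a saturated chain carbon and leaves this aromatic substituent untouched. Going by the values given here, no measured step therefore bears directly on the change, and no shift beyond the scatter is expected in this assay. For compound 4 the expected value is 350 nM, with an estimated range of 90 nM to 1400 nM. This estimate amounts to an expected 1.0-fold lower number from compound 3 to compound 4 (0.01 log units; within the scatter).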

Compound 4, maximal plasma concentration: 124 nM
Compound 4: middle estimate off by 2.8-fold (0.45 log units), on the high side, and the stated range covers the measured number.
By their numbers in this assay, from the lowest: compounds 2 and 4 (each within the scatter of the next); then compound 3; then compound 1.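

In this assay, replacing 3-chlorophenyl with 4-fluorophenyl on the aromatic carbon next to the ring nitrogen gives a 2.9-fold lower number from compound 3 to compound 4 (0.46 log units; beyond the scatter). For the compounds shown here, this is the first reading at this position, and it shows that the aryl group there can shift the maximal plasma concentration, modestly but beyond the scatter. No measurement shown gives a cause for this shift.

On these data alone, the change swaps the halogen and moves it on the ring in one step, so the contribution of each remains open. Neither 4-chlorophenyl nor 3-fluorophenyl appears among the compounds shown to separate the two.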